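The compounds below may be only part of what the source reports. "The series", "measured", "known", "first", "only" and "open" are said of these compounds alone.

Working notes on the series, read in a functional assay on HepG2 cells (Homo sapiens) for inhibition, read by fluorescence and resazurin assay, with a stated time of 72 h; a higher number here means a weaker inhibitor, a lower number a stronger inhibitor. Compound 1 `O=C(Nc1ccccc1)Nc1cccc(Nc2nccc(Nc3ccc4nc[nH]c4c3)n2)c1` gives 11000 nM, compound 2 `O=C(Nc1ccccc1)Nc1cccc(Nc2nccc(Nc3ccc4cn[nH]c4c3)n2)c1` gives 8200 nM and compound 3 `Cc1ccc(NC(=O)Nc2cccc(Nc3nccc(Nc4ccc5cn[nH]c5c4)n3)c2)cc1` gives 11000 nM. These values lie within the scatter of one another, so compound 2 stands apart from neither of the other two.

Compound 4 `Cc1ccc(Nc2nccc(Nc3ccc4cn[nH]c4c3)n2)cc1NC(=O)Nc1ccccc1` differs from compound 2 by one change: methyl in place of hydrogen on an aromatic carbon. This is methyl in place of hydrogen on an aromatic carbon, ortho to a (phenylcarbamoyl)amino group and para to a large group.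

Going by the values given here, the only measured precedent for this swap, made at a different place on the structure, is a 1.3-fold higher number from compound 2 to compound 3 (0.13 log units; within the scatter). Among the compounds with values here, the other measured step, a 1.3-fold lower number from compound 1 to compound 2 (0.13 log units; within the scatter), involves a different change and bears on this one only as a further sign of a flat series so far. No measurement covers a methyl at the new place, so the range is kept wide.

No step beyond the scatter is expected. For compound 4 the estimated step is a 1.2-fold higher number from compound 2 to compound 4 (0.06 log units; within the scatter). For compound 4 the expected value is 9500 nM, with an estimated range of 4000 nM to 22000 nM.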

Compound 4, half-maximal inhibitory concentration: 8900 nM
For compound 4 the middle estimate is 1.1-fold (0.03 log units) above the measured one; the range from low to high includes it.
By their numbers in this assay, from the lowest: compounds 2, 4, 1 and 3 (each within the scatter of the next).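

In this assay, going by these compounds alone, methyl in place of hydrogen on the aromatic carbon ortho to a (phenylcarbamoyl)amino group and para to a large group gives a 1.1-fold higher number from compound 2 to compound 4 (0.04 log units; within the scatter), so the first reading at this place shows no step beyond the scatter. Alongside a 1.3-fold higher number from compound 2 to compound 3 (0.13 log units; within the scatter), there are now two places on the structure where this same swap stays within the scatter, and neither compound 3 nor compound 4 goes against that. Nothing measured bears on why the number stays flat at this position.

Methyl is the only group shown at this aromatic carbon, so it remains open whether a chlorine, a methoxy group, an amine or a carboxylic acid there would give a step beyond the scatter. No step among the compounds shown leaves the scatter, so they do not yet identify any part of the structure on which the number depends.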